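This account rests on a few compounds, and the source may have more. Where it says the series, first, only, none or still open, it means among the compounds named here.

Compound 1 `O=C(O)CNC(=O)[C@]1(O)C[C@@H](O)[C@@H](O)[C@H](O)C1`: 38%
Compound 2 `O=C(O)CCCNC(=O)[C@]1(O)C[C@@H](O)[C@@H](O)[C@H](O)C1`: 83%

Within the data shown here, of the two compounds measured in an assay on HL-60 cells for inhibition of P-selectin (Homo sapiens), tested at 50 mM (a lower number here means less inhibition, a higher number more inhibition at the concentration tested (going by the name of the read-out)), compound 2 stands highest; its nearest neighbour is compound 1, and the single step between them, a number 45 percentage points higher from compound 1 to compound 2 (beyond the scatter), lies beyond the scatter. Compound 3 `O=C(O)CCCCCNC(=O)[C@]1(O)C[C@@H](O)[C@@H](O)[C@H](O)C1` differs from compound 2 by 2-carboxyethyl in place of carboxy on a saturated chain carbon, three bonds along the chain from an amide-type nitrogen. Among the measured compounds shown here, the only measured step that bears on this change is a number 45 percentage points higher from compound 1 to compound 2 (beyond the scatter), a large gain on lengthening the same chain. Compound 2 already gives 83%, which leaves little room upward. The step to compound 3 is therefore expected to be small, a number 2 percentage points higher from compound 2 to compound 3 (within the scatter), within the scatter. Compound 3 is estimated at 85%, ranging from 65% to 98%.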

Compound 3, a percentage reported as inhibition, at one concentration (the size of the read-out at that concentration, not a potency): 14%
Beside the measured number, compound 3's estimate is 71 percentage points above it; measured number outside the range, below it.
By their numbers in this assay, from the lowest: compound 3; then compound 1; then compound 2.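

In this assay, lengthening this chain does not keep paying: 2-carboxyethyl in place of carboxy, three bonds along the chain from an amide-type nitrogen, gives a number 69 percentage points lower from compound 2 to compound 3 (beyond the scatter) and reverses the earlier gain. The longest chain also falls behind the shortest, with a number 24 percentage points lower from compound 1 to compound 3 (beyond the scatter) on this change, so among these three compounds the highest number belongs to the chain of compound 2. Nothing available accounts for this reversal. As far as these compounds go, whether an amine in place of the carboxy group would keep the inhibition of compound 2 remains open, as does the effect of an ether oxygen within the chain.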